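The compounds below may be only part of what the source reports. "The series", "measured", "known", "first", "only" and "open" are said of these compounds alone.

Measured so far in an ADME assay on BaF3 cells (Mus musculus) for antiproliferative activity, read by CCK-8 assay, with a stated time of 72 h; on this read-out higher numbers stand for weaker inhibition of growth and lower numbers for stronger inhibition of growth:
- compound 1 `O=C(CCSc1ccc2c(/C=C/c3ccccn3)n[nH]c2c1)Nc1ccccc1` gives 690 nM
- compound 2 `CN(C)c1cccc(NC(=O)CCSc2ccc3c(/C=C/c4ccccn4)n[nH]c3c2)c1` gives > 10000 nM as a limit of the assay
- compound 3 `O=C(CCSc1ccc2c(/C=C/c3ccccn3)n[nH]c2c1)Nc1ccc(F)c(C(F)(F)F)c1` gives 610 nM

Within the data shown here, compound 3 stands level with compound 1 within the scatter (a 1.1-fold lower number from compound 1 to compound 3 (0.05 log units; within the scatter)), and these two are the only numerical values in the set. Compound 2 lies far from compound 3 (an at least 16-fold lower number from compound 2 to compound 3 (1.21 log units; beyond the scatter)), and its entry is only a limit.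

Compound 4 `CC1CCN(Cc2ccc(NC(=O)CCSc3ccc4c(/C=C/c5ccccn5)n[nH]c4c3)cc2C(F)(F)F)CC1` carries (4-methylpiperidin-1-yl)methyl in place of fluoro on an aromatic carbon, ortho to a trifluoromethyl group and para to a large group ((4-methylpiperidin-1-yl)methyl in place of fluoro on an aromatic carbon).

Among the measured compounds shown here, two measured steps bear on this change, and both alter the same aromatic ring. The change from phenyl to 4-fluoro-3-(trifluoromethyl)phenyl made no difference beyond the scatter (a 1.1-fold lower number from compound 1 to compound 3 (0.05 log units; within the scatter)). Dimethylamino in place of hydrogen gave a large rise (an at least 14-fold higher number from compound 1 to compound 2 (1.16 log units; beyond the scatter)), but that group is not the one entering compound 4, so this step is only a loose guide. The two steps point in different directions and neither matches the new change closely, so no step beyond the scatter is the central expectation, with wide uncertainty on both sides. The expected step is a 1.2-fold lower number from compound 3 to compound 4 (0.09 log units; within the scatter) in this assay on this reasoning. For compound 4 the estimated value is 500 nM with an expected range from 60 nM to 6000 nM on this read-out.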

Compound 4, concentration for 50% growth inhibition: 4170 nM
The estimate for compound 4 lay 8.3-fold (0.92 log units) below the measured number; low and high end bracket the measured number.
By their numbers in this assay, from the lowest: compounds 3 and 1 (each within the scatter of the next); then compound 4. At a limit, above all of these: compound 2.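

In this assay, this aromatic carbon, ortho to a trifluoromethyl group and para to a large group, is sensitive to what it carries: replacing fluoro with (4-methylpiperidin-1-yl)methyl gives a 6.8-fold higher number from compound 3 to compound 4 (0.83 log units; beyond the scatter). The earlier change to this ring, a 1.1-fold lower number from compound 1 to compound 3 (0.05 log units; within the scatter), stayed within the scatter, so the tolerance seen for fluoro and trifluoromethyl does not extend to a group of 8 heavy atoms with a six-membered non-aromatic ring. The cost is modest, and compound 4 still gives a number rather than a limit, but nothing measured here accounts for the rise.

From the compounds shown here alone, it remains open whether the rise follows from the ring nitrogen or from the carbon framework of the entering group, a question that cyclohexylmethyl or morpholin-4-ylmethyl at this carbon would help to settle. Going by these compounds, it also remains open whether a shorter link, such as the piperidine ring attached directly to the aromatic carbon, or the same (4-methylpiperidin-1-yl)methyl group without the trifluoromethyl group would read the same way.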